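A few compounds are considered here, and "the series" means these few. Any claim that something is new, unique, unknown or untested is made for them only; others in the source may bear on it.

Measured compounds:
- compound 1 `Nc1cc(N)c2nc(-c3ccccc3)c(NCc3ccc(Cl)c(Cl)c3)nc2c1`, in a functional assay on HCT-15 cells (Homo sapiens) for inhibition, read by sulforhodamine B assay, with a stated time of 48 h (a lower number here means that less compound is tolerated, a higher number that more compound is tolerated), compound 1 gives < 100000 nM, a limit of the assay rather than a number.
- compound 2 `CCOC(=O)[C@H](CCC(=O)O)NC(=O)c1ccc(Sc2nc3cc(N)cc(N)c3nc2-c2ccccc2)cc1`; compound 2 gives < 100000 nM, again a limit.
- compound 3 `COc1cc(CNc2nc3cc(N)cc(N)c3nc2-c2ccccc2)cc(OC)c1OC`; compound 3 gives < 50200 nM, also a limit.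

None of the three values is a measured number; each is only a boundary the assay reports. Two of them sit at the limit of < 100000 nM in this assay, at which 2 of the 3 values shown sit, and compound 3 alone sits at the limit of < 50200 nM in this assay, at which 1 of the 3 values shown sits. So compound 3 cannot be placed above or below the other two on these numbers, and no measured step between any pair of compounds exists.

Compound 4 `COc1ccc(CNc2nc3cc(N)cc(N)c3nc2-c2ccccc2)cc1OC` is not yet measured. It differs from compound 3 in one place: hydrogen in place of methoxy on an aromatic carbon. Among the compounds with values here, with no measured step to draw on, the expectation rests on the change itself, which is small. In this assay the step from compound 3 to compound 4 is expected to be a step that the limit leaves unreadable from compound 3 to compound 4, that is, none beyond the usual scatter. Compound 4 is therefore estimated at 30000 nM, within 5000 nM to 100000 nM, and there is a fair chance that only a limit is reported.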

Compound 4, concentration lethal to 50% of the cells: < 100000 nM
Compound 4 gave a limit, no number; the forecaster's own chance of this, stated with the estimate: 60%; the middle value is on the limit's open side.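

Compound 4 also gives only a limit of the assay, and the steps linking it to compound 3 and to compound 1 cannot be read. Still open, on these data alone, is whether hydrogen in place of methoxy, or 3,4-dimethoxyphenyl in place of 3,4-dichlorophenyl, changes the result in this assay at all.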